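A few compounds are considered here, and "the series" means these few. Any claim that something is new, unique, unknown or untested is made for them only; others in the source may bear on it.

In a functional assay on Caco-2 cells (Homo sapiens) for inhibition, read by sulforhodamine B assay, with a stated time of 48 h (a higher number here means a weaker inhibitor, a lower number a stronger inhibitor), compound 2 `O=C1[C@H]2[C@H](ON(c3ccccc3)[C@@H]2c2coc3ccc(F)cc3c2=O)C(=O)N1c1ccccc1` reaches only the limit of the assay, > 60000 nM, so no true number is known for it. Compound 1 `CCO[C@H]1C[C@@H](c2coc3ccccc3c2=O)N(c2ccccc2)O1` likewise stops at the limit > 60000 nM in this assay. Compound 3 `CCO[C@H]1C[C@@H](c2coc3cc(Cl)c(Cl)cc3c2=O)N(c2ccccc2)O1` also gives only the limit > 60000 nM in this assay. All three measured compounds thus stand together at the limit of > 60000 nM in this assay, at which 3 of the 3 values shown sit, and nothing separates them. Compound 4 `Cc1ccc2occ([C@@H]3[C@H]4C(=O)N(c5ccccc5)C(=O)[C@H]4ON3c3ccccc3)c(=O)c2c1` is obtained from compound 2 by the change (methyl in place of fluoro on an aromatic carbon), methyl in place of fluoro on an aromatic carbon. For the measured compounds named here, no pair of measured compounds differs in one place, so no step is known; the estimated step is a step that the limit leaves unreadable from compound 2 to compound 4, nothing beyond the scatter. Compound 4 is expected to show about 80000 nM in this assay, between 30000 nM and 200000 nM, most likely again only as a limit.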

Compound 4, half-maximal inhibitory concentration: > 60000 nM
Compound 4 ended at the assay's limit (the forecaster's own chance of this, stated with the estimate: 85%); the middle value lies beyond the limit too.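

Compound 2 and compound 4 both stop at a limit, so no step can be read between them: the limit of > 60000 nM in this assay, at which 4 of the 4 values shown sit. The compounds shown leave open how strongly any of them inhibits in this assay, and what methyl in place of fluoro changes.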